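Swapping the aryl on the ring nitrogen of compound 1

This account rests on a few compounds, and the source may have more. Where it says the series, first, only, none or still open, it means among the compounds named here.

Measured so far in a functional assay on CHO cells with adenosine receptor A1 (Homo sapiens) as the target, read by cAMP accumulation and immunoassay, with a stated time of 6 min, tested at 0.1 uM; on this read-out higher numbers stand for a weaker effect at the one concentration tested and lower numbers for a stronger effect:
compound 1 `Nc1scc(CN2CCN(c3ccc(Cl)cc3Cl)CC2)c1C(=O)c1ccc(Cl)cc1` gives -11%;
compound 2 `Nc1scc(CN2CCN(c3ccc(F)cc3Cl)CC2)c1C(=O)c1ccc(Cl)cc1` gives -6.2%;
compound 3 `Nc1scc(CN2CCN(c3cccc(C(F)(F)F)c3)CC2)c1C(=O)c1ccc(Cl)cc1` gives -30%.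

On these numbers compound 1 stands second highest of the three, nearest to compound 2 and furthest from compound 3. Compound 4 `Nc1scc(CN2CCN(c3cccc(F)c3)CC2)c1C(=O)c1ccc(Cl)cc1` differs from compound 1 by 3-fluorophenyl in place of 2,4-dichlorophenyl on an amine nitrogen in a ring. Among the compounds with values here, two measured steps bear on this change. Exchanging the aryl on the ring nitrogen gave a number 19 percentage points lower from compound 1 to compound 3 (beyond the scatter), beyond the scatter, whereas exchanging one halogen for another gave a number 4.8 percentage points higher from compound 1 to compound 2 (within the scatter), within it. The 3-fluorophenyl carries a single group, as does the 3-(trifluoromethyl)phenyl of compound 3, but that group is fluorine rather than trifluoromethyl, so a lower number is expected, though smaller than the step to compound 3. The expected step is estimated as a number 9 percentage points lower from compound 1 to compound 4 (within the scatter). For compound 4 the estimate is -20%, with a range from -36% to -4%.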

Compound 4, a percentage reported as activity, at one concentration (the size of the read-out at that concentration, not a potency): -37%
Compound 4: middle estimate off by 17 percentage points, on the high side; measured number below the stated range.
By their numbers in this assay, from the lowest: compounds 4 and 3 (each within the scatter of the next); then compounds 1 and 2 (each within the scatter of the next).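

In this assay the exchange of aryl on the amine nitrogen gave a number 26 percentage points lower from compound 1 to compound 4 (beyond the scatter) and a number 30.8 percentage points lower from compound 2 to compound 4 (beyond the scatter), so the lower number seen with compound 3 is not tied to trifluoromethyl. Fluoro in place of trifluoromethyl gave a number 7 percentage points lower from compound 3 to compound 4 (within the scatter), which leaves the two phenyl rings carrying a single group unseparated on this read-out. No measurement shown accounts for this shift. The compounds shown leave open whether an unsubstituted phenyl or a 3-methoxyphenyl would read like compound 4. They also leave open whether a pyridine in place of the phenyl would keep the lower number.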